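Toward compound 4: a chloro aryl on the shared core

The compounds below may be only part of what the source reports. "The series", "measured", "known", "first", "only" and "open" are said of these compounds alone.

Measured compounds in a functional assay on MCF7 cells (Homo sapiens) for cytotoxicity, read by MTT assay, with a stated time of 72 h; on this read-out lower numbers stand for an effect already at smaller amounts and higher numbers for an effect only at larger amounts of compound:
compound 1 `O=C1/C(=C\c2ccc(O)cc2)c2ccccc2N1c1c(Cl)cccc1Cl`: 20 ug/mL
compound 2 `CN(C)c1ccc(/C=C2\C(=O)N(c3c(Cl)cccc3Cl)c3ccccc32)cc1`: > 100 ug/mL, a limit of the assay
compound 3 `O=C1/C(=C\c2ccccc2[N+](=O)[O-])c2ccccc2N1c1c(Cl)cccc1Cl`: "not determined" (no result reported)

Compound 3 stands without a number. In this assay compound 3 gives "not determined" (no result reported), so it has no place among the measured values, and it cannot be set against compound 1 or compound 2 in any direction. Compound 4 `O=C1/C(=C\c2ccc(Cl)cc2)c2ccccc2N1c1c(Cl)cccc1Cl` differs from compound 3 by 4-chlorophenyl in place of 2-nitrophenyl on a double-bonded chain carbon bound to a double-bonded ring carbon.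

Among the measured compounds shown here, the one measured step on the shared core concerns the group on the aryl ring bound to the chain carbon: an at least 5.0-fold higher number from compound 1 to compound 2 (0.69 log units; beyond the scatter). For the measured compounds named here, that step is the only guide to how a change on this ring can move the read-out, and it shows that such a change can be modest or larger. It does not involve either the 2-nitrophenyl or the 4-chlorophenyl of the present change, and compound 2 sits at the limit of > 100 ug/mL in this assay, at which 1 of the 3 values shown sits, so its true size is open. Going by the values given here, no measured step bears directly on the change from compound 3 to compound 4, and the direction of the step cannot be estimated from the values shown.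

For compound 4 in this assay the expected value is 40 ug/mL, with a range from 10 ug/mL to 100 ug/mL, resting on compound 1 at 20 ug/mL as the only numeric anchor on this core.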

Compound 4, concentration for half-maximal effect: 5 ug/mL
Compound 4: middle estimate off by 8.0-fold (0.90 log units), on the high side; measured number outside the range, below it.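

In this assay, the earlier step had shown only that a change on this aryl ring can raise the number, whereas chloro in place of hydroxy now moves the read-out the other way, with a 4.0-fold lower number from compound 1 to compound 4 (0.60 log units; beyond the scatter). Chloro in place of dimethylamino gives an at least 20-fold lower number from compound 2 to compound 4 (1.30 log units; beyond the scatter), so the three groups at this one ring place, hydroxy, dimethylamino and chloro, give clearly separated read-outs on the shared core. Compound 2 enters that comparison only through a limit, so the true size of its step stays open: the limit of > 100 ug/mL in this assay, at which 1 of the 4 values shown sits.

The step from compound 3 to compound 4 cannot be read, since compound 3 has no reported result, and the 2-nitrophenyl therefore remains unplaced against the 4-chlorophenyl. From the compounds shown here alone, it also remains open whether the lower number belongs to chloro in particular or would also appear with a bromo, a methoxy or a carboxylic acid in the same place on the ring.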